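Replacing an isopropoxy chain with a diethylaminopropoxy chain

The source may report more compounds than this note shows. Statements on the series, on what has been measured and on what is new or still open speak of the compounds shown alone.

Measured compounds:
- Compound 1, `CCCCOc1c(-c2cc(OC)c(OC)c(OC)c2)oc2ccccc2c1=O`, 8900 nM
- Compound 2, `CCCCCOc1c(-c2cc(OC)c(OC)c(OC)c2)oc2ccccc2c1=O`, 15400 nM
- Compound 3, `COc1cc(-c2oc3ccccc3c(=O)c2OC(C)C)cc(OC)c1OC`, 8800 nM

Three compounds sharing one core were tested in a functional assay on LNCaP cells (Homo sapiens) for antiproliferative activity, read by WST assay, with a stated time of 3 days; on this read-out lower numbers stand for stronger inhibition and higher numbers for weaker inhibition. They differ only in the alkyl group on an oxygen on an aromatic ring. Compound 3, with an isopropyl group there, gives 8800 nM, the lowest of the three numbers, but its steps to the others are within the scatter: a 1.0-fold lower number from compound 1 to compound 3 (0.00 log units; within the scatter) and a 1.8-fold lower number from compound 2 to compound 3 (0.24 log units; within the scatter). Likewise a 1.7-fold higher number from compound 1 to compound 2 (0.24 log units; within the scatter). So far, changing the length or branching of this chain has moved nothing that can be told apart from repeat measurement.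

Compound 4, `CCN(CC)CCCOc1c(-c2cc(OC)c(OC)c(OC)c2)oc2ccccc2c1=O`, is not yet measured. It differs from compound 3 as 3-(diethylamino)propyl in place of isopropyl on an oxygen on an aromatic ring. For the measured compounds named here, the entering group carries a nitrogen, something none of the measured chains contain, so no measured step bears directly on it; the only guidance is that butyl, pentyl and isopropyl on this oxygen all gave numbers within the scatter of one another. The expected step is therefore none beyond the scatter, a 1.0-fold higher number from compound 3 to compound 4 (0.01 log units; within the scatter), though the new group leaves room for a larger move in either direction. For compound 4 the estimate in this assay is 9000 nM, expected to lie between 2500 nM and 32000 nM.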

Compound 4, half-maximal inhibitory concentration: 37600 nM
Compound 4: middle estimate off by 4.2-fold (0.62 log units), on the low side; measured number outside the range, above it.
By their numbers in this assay, from the lowest: compounds 3, 1 and 2 (each within the scatter of the next); then compound 4.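

For the compounds shown here, the 3-(diethylamino)propyl chain gives the only steps at this position in this assay that lie beyond the scatter: a 4.3-fold higher number from compound 3 to compound 4 (0.63 log units; beyond the scatter), a 4.2-fold higher number from compound 1 to compound 4 (0.63 log units; beyond the scatter) and a 2.4-fold higher number from compound 2 to compound 4 (0.39 log units; beyond the scatter). The oxygen on the aromatic ring therefore does not accept every chain alike: butyl, pentyl and isopropyl stay within the scatter of one another, while this chain carrying a nitrogen gives a modestly higher number, meaning weaker inhibition, than all three. Nothing measured here accounts for this rise.

On these data alone, compound 4 differs from the other compounds in both the size of its chain and the presence of nitrogen, so it remains open which of these goes with the higher number; an octyl chain, which has no nitrogen, would help to separate the two. Also open, as far as these compounds go, is how a shorter 2-(diethylamino)ethyl chain, or a chain ending in dimethylamino or a carboxylic acid, would read out, and whether any group on this oxygen can bring the number clearly below those of the simple chains.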